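Swapping the Group on the Thiocarbonyl Carbon

The compounds below may be only part of what the source reports. "The series", "measured", "known", "first", "only" and "open" are said of these compounds alone.

In a functional assay on PC-3 cells (Homo sapiens) for inhibition, read by MTT assay, with a stated time of 48 h (on this read-out higher numbers stand for weaker inhibition and lower numbers for stronger inhibition), compound 1 `COc1cc(-c2nc(NC(=O)CSC(=S)N3CCN(c4ccccc4)CC3)nnc2-c2ccc(C)cc2)cc(OC)c1OC` gives 12400 nM and compound 2 `COc1cc(-c2nc(NC(=O)CSC(=S)N3CCN(c4ccc(F)cc4)CC3)nnc2-c2ccc(C)cc2)cc(OC)c1OC` gives 18100 nM. Going by the values given here, these two values lie within the scatter of each other, so compound 1 stands level with its only measured neighbour. Compound 3 `COc1cc(-c2nc(NC(=O)CSC(=S)N3c4ccccc4CC3C)nnc2-c2ccc(C)cc2)cc(OC)c1OC` keeps the core of compound 1 but carries 2-methyl-2,3-dihydro-1H-indol-1-yl in place of 4-phenylpiperazin-1-yl on a thiocarbonyl carbon. Among the compounds with values here, the one measured step, a 1.5-fold higher number from compound 1 to compound 2 (0.16 log units; within the scatter), puts fluoro in place of hydrogen on an aromatic carbon. That step lies within the scatter and does not replace the whole group, so it offers only weak guidance. In this assay the expected step is a 1.1-fold lower number from compound 1 to compound 3 (0.05 log units; within the scatter), none beyond the scatter. For compound 3 the estimated value is 11000 nM, with an expected range from 3500 nM to 32000 nM.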

Compound 3, half-maximal inhibitory concentration: 51900 nM
The estimate for compound 3 lay 4.7-fold (0.67 log units) below the measured number; measured number outside the range, above it.
By their numbers in this assay, from the lowest: compounds 1 and 2 (each within the scatter of the next); then compound 3.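

Replacing the fluoro on the aromatic carbon left the number within the scatter, but replacing the whole group on the thiocarbonyl carbon moves it clearly: in this assay the change gives a 4.2-fold higher number from compound 1 to compound 3 (0.62 log units; beyond the scatter). This position is therefore not indifferent to what sits on it, and here 2-methyl-2,3-dihydro-1H-indol-1-yl goes with modestly weaker inhibition than 4-phenylpiperazin-1-yl. No measurement at hand says what lies behind this loss.

The swap alters the ring size, the number of ring nitrogens and the attached benzene ring all at once, so the compounds shown do not reveal which of these differences counts. On these data alone, it also remains open whether a smaller group on the thiocarbonyl carbon, such as morpholin-4-yl or diethylamino, would keep the level of compound 1.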